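Changing the Sulfonamide Ring of Compound 2

A few compounds are considered here, and "the series" means these few. Any claim that something is new, unique, unknown or untested is made for them only; others in the source may bear on it.

In a functional assay on OVCAR-3 cells (Homo sapiens) for antiproliferative activity, read by sulforhodamine B assay, with a stated time of 72 h (a lower number here means a stronger inhibitor, a higher number a weaker inhibitor), compound 2 (`O=S(=O)(Nc1ncccn1)c1ccc(Nc2nncc3ccccc23)cc1`) gives 72 nM. That lies within the scatter of compound 1 (`CCN1C(=O)CS/C1=N/Nc1nncc2ccccc12`) at 55 nM and compound 3 (`O=C1CS/C(=N/Nc2nncc3ccccc23)N1`) at 46 nM. Compound 4 (`Cc1cc(NS(=O)(=O)c2ccc(Nc3nncc4ccccc34)cc2)no1`) has 5-methyl-1,2-oxazol-3-yl in place of pyrimidin-2-yl on a sulfonamide nitrogen. Within the data shown here, no measured step covers this change. Among the measured compounds shown here, the one step available, a 1.2-fold lower number from compound 1 to compound 3 (0.08 log units; within the scatter), puts hydrogen in place of ethyl on an amide-type nitrogen in a ring, so it offers only indirect guidance and stays within the scatter. No shift beyond the scatter is therefore expected in this assay, and the expected step is a 1.0-fold lower number from compound 2 to compound 4 (0.01 log units; within the scatter). Compound 4 is estimated at 70 nM, with an expected range of 30 nM to 160 nM.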

Compound 4, half-maximal inhibitory concentration: 54 nM
The estimate for compound 4 lay 1.3-fold (0.11 log units) above the measured number, within the range that was stated.
By their numbers in this assay, from the lowest: compounds 3, 4, 1 and 2 (each within the scatter of the next).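

The sulfonamide nitrogen now has its first measured step: 5-methyl-1,2-oxazol-3-yl in place of pyrimidin-2-yl gives a 1.3-fold lower number from compound 2 to compound 4 (0.12 log units; within the scatter) in this assay and so no shift beyond the scatter. On this nitrogen, then, a five-membered aromatic ring can stand in for a six-membered one without a clear change in this assay. No measurement shown explains why the two rings read alike. Still open, from the compounds shown here alone, is how a non-aromatic group on this nitrogen, such as methyl or acetyl, would read. Going by these compounds, a plain hydrogen there, or a carboxylic acid on the ring, is equally open.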